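Methyl to tert-Butyl on the Thioether Aryl of Compound 1

The source may hold more compounds than are shown below. What is called first, only, known or untested is meant among the compounds shown, and "the series" means these compounds.

This account follows a single change made to compound 1 `Cc1ccc(SCc2ccc(/C=C/C(=O)Nc3ccccc3N)cc2)cc1`. In a functional assay on HCT-116 cells (Homo sapiens) for inhibition, read by CCK-8 assay, with a stated time of 72 h, tested at 2 uM (a lower number here means less inhibition of growth, a higher number more inhibition of growth at the concentration tested), compound 1 gives 6.23%, the lowest of the three numbers in hand. Compound 2 `Nc1ccccc1NC(=O)c1ccc(CSc2ccc(Br)cc2)cc1` gives 9.96%, within the scatter of compound 1, while compound 3 `COc1ccc(SCc2ccc(C(=O)Nc3ccccc3N)cc2)cc1` gives 73.3%. Among the measured compounds shown here, the one measured step, a number 63.3 percentage points higher from compound 2 to compound 3 (beyond the scatter), shows that a substituent at this place can move the number far, but it swaps a halogen for an ether, not one alkyl for another. Compound 4 `CC(C)(C)c1ccc(SCc2ccc(/C=C/C(=O)Nc3ccccc3N)cc2)cc1` differs from compound 1 by tert-butyl in place of methyl on an aromatic carbon. For the measured compounds named here, no measured step involves an alkyl-for-alkyl swap, so a step within the scatter is expected, a number 3.8 percentage points higher from compound 1 to compound 4 (within the scatter). Compound 4 is therefore estimated at 10%, between 0% and 35%.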

Compound 4, percent growth inhibition at one concentration: 6.66%
The estimate for compound 4 lay 3.3 percentage points above the measured number; the measured number falls inside the stated range.
By their numbers in this assay, from the lowest: compounds 1, 4 and 2 (each within the scatter of the next); then compound 3.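

In this assay, the step is a number 0.4 percentage points higher from compound 1 to compound 4 (within the scatter), so on the core of compound 1 the larger tert-butyl group in place of methyl leaves the number where it was. The earlier compounds shown here showed a large step only for methoxy in place of bromo, on another core, and none showed an alkyl-for-alkyl swap. No data at hand bear on this result.

On these data alone, whether an amine or a carboxylic acid at this place on the core of compound 1 would move the number stays open.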